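Swapping the Aryl Ketone Partner on a Benzoxaborole Chalcone

The source may report more compounds than this note shows. Statements on the series, on what has been measured and on what is new or still open speak of the compounds shown alone.

Compound 2 `O=C(/C=C/c1ccc2c(c1)B(O)OC2)c1ccc(I)cc1` was tested in a functional assay on SK-OV-3 cells (Homo sapiens) for cytotoxicity, read by MTT assay, with a stated time of 48 h (a higher number here means a weaker inhibitor, a lower number a stronger inhibitor), where compound 2 gives 4200 nM. Among the measured compounds shown here, that is the lower of the two numbers so far: its only neighbour is compound 1 `Cn1cccc1C(=O)/C=C/c1ccc2c(c1)B(O)OC2`, which in this assay gives 93600 nM, a step of a 22-fold lower number from compound 1 to compound 2 (1.35 log units; beyond the scatter). Compound 3 `O=C(/C=C/c1ccc2c(c1)B(O)OC2)c1ccccc1F` keeps the shared core and differs from compound 2 in one place: 2-fluorophenyl in place of 4-iodophenyl on a carbonyl carbon. For the measured compounds named here, the single measured step exchanges a heteroaromatic ring for a halogenated phenyl and was large, but it does not tell how two halogenated phenyl rings compare, so no step size can be read straight from it. With only one substituted phenyl measured, the estimate for compound 3 stays close to compound 2, leaning somewhat weaker, a step of a 2.4-fold higher number from compound 2 to compound 3 (0.38 log units; beyond the scatter); the expected value is 10000 nM, within 3000 nM to 40000 nM.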

Compound 3, half-maximal inhibitory concentration: 3700 nM
For compound 3 the middle estimate is 2.7-fold (0.43 log units) above the measured one; the range from low to high includes it.
By their numbers in this assay, from the lowest: compounds 3 and 2 (each within the scatter of the next); then compound 1.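

In this assay, 2-fluorophenyl in place of 4-iodophenyl on the carbonyl carbon gives a 1.1-fold lower number from compound 2 to compound 3 (0.06 log units; within the scatter), so these two halogenated phenyl rings cannot be told apart here, even though the halogen differs. The change from the 1-methyl-1H-pyrrol-2-yl group gives a 25-fold lower number from compound 1 to compound 3 (1.40 log units; beyond the scatter), which is also large, so the large step now appears with two different halogenated phenyl rings and does not rest on the 4-iodophenyl group alone. Nothing measured here gives a reason for either result.

On these data alone, it remains open whether a plain phenyl ring with no halogen would fall with compound 2 and compound 3 or closer to compound 1. Also open, as far as these compounds go, is how a phenyl ring carrying an amine or a carboxylic acid would behave at this position.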